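Series notes: from compound 2 to compound 4

The source may hold more compounds than are shown below. What is called first, only, known or untested is meant among the compounds shown, and "the series" means these compounds.

Compound 2 `O=S(=O)(NCCCNCC1COc2ccccc2O1)c1cc(C(F)(F)F)cc(C(F)(F)F)c1` gives 2500 nM in a functional assay on MCF7 cells (Homo sapiens) for inhibition, read by MTT assay, with a stated time of 72 h; a lower number here means a stronger inhibitor of growth, a higher number a weaker inhibitor of growth. Going by the values given here, of the three numbers measured so far, compound 2 stands second highest: compound 1 `O=S(=O)(NCCNCc1ccc(-c2ccccc2)cc1)c1cc(C(F)(F)F)cc(C(F)(F)F)c1` gives 1400 nM, within the scatter of compound 2, while compound 3 `CC(C)(C)c1ccc(CNCCNS(=O)(=O)c2cc(C(F)(F)F)cc(C(F)(F)F)c2)cc1` gives 13000 nM, beyond it. Among the compounds with values here, the only single-point step measured is a 9.3-fold higher number from compound 1 to compound 3 (0.97 log units; beyond the scatter). Compound 4 `COc1ccccc1CNCCCNS(=O)(=O)c1cc(C(F)(F)F)cc(C(F)(F)F)c1` differs from compound 2 by 2-methoxyphenyl in place of 2,3-dihydro-1,4-benzodioxin-2-yl on a saturated chain carbon bound to an amine nitrogen. Within the data shown here, no measured step bears on this change; the step from compound 1 to compound 3 concerns a different group and offers no direction here. The expected step in this assay is therefore none beyond the scatter, so compound 4 is estimated at 2500 nM, with a range of 900 nM to 7000 nM. This amounts to an expected step of no change at the digits printed from compound 2 to compound 4 (within the scatter).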

Compound 4, concentration for 50% growth inhibition: 2600 nM
For compound 4 the middle estimate is 1.0-fold (0.02 log units) below the measured one; low and high end bracket the measured number.
By their numbers in this assay, from the lowest: compounds 1, 2 and 4 (each within the scatter of the next); then compound 3.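

In this assay, the exchange of 2,3-dihydro-1,4-benzodioxin-2-yl for 2-methoxyphenyl on this saturated chain carbon gives a 1.0-fold higher number from compound 2 to compound 4 (0.02 log units; within the scatter). Going by these compounds alone, this place therefore accepts the loss of the six-membered non-aromatic ring, and of one hydrogen-bond acceptor from the count, without a step beyond the scatter, which the earlier compounds could not show. Nothing measured here accounts for this result. Still open, going by these compounds, is whether a carboxylic acid in place of 2-methoxyphenyl, or a longer chain at this place, would keep the number of compound 4.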